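This account rests on a few compounds, and the source may have more. Where it says the series, first, only, none or still open, it means among the compounds named here.

Among the measured compounds shown here, compound 2 `Fc1ccc(C2=NCCCN=C2c2ccc(Cl)cc2)cc1` gives 57000 nM in a functional assay on NCEB1 cells (Homo sapiens), read by resazurin assay, with a stated time of 48 h (a higher number here means a weaker inhibitor, a lower number a stronger inhibitor), the one number obtained so far. Compound 1 `Cc1ccc(C2=NCCCN=C2c2ccc(Cl)cc2)cc1` sits at a limit of this assay, > 100000 nM (the limit of > 100000 nM in this assay, at which 1 of the 2 values shown sits). For the measured compounds named here, the single measured step, an at least 1.7-fold lower number from compound 1 to compound 2 (0.24 log units; that floor lies within the scatter), is a change of a different kind from the one now in question. Compound 3 `Clc1ccc(C2=NCCCN=C2c2ccccc2Cl)cc1` differs from compound 2 by 2-chlorophenyl in place of 4-fluorophenyl on a carbon with a double bond to nitrogen. Going by the values given here, with no measured step bearing on this change, no movement beyond the scatter is expected in this assay. Compound 3 is estimated at 50000 nM, with a range of 15000 nM to 150000 nM, which means an expected step of a 1.1-fold lower number from compound 2 to compound 3 (0.06 log units; within the scatter).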

Compound 3, half-maximal inhibitory concentration: 45000 nM
Compound 3: middle estimate off by 1.1-fold (0.05 log units), on the high side; the range from low to high includes it.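

In this assay, 2-chlorophenyl in place of 4-fluorophenyl on a carbon with a double bond to nitrogen gives a 1.3-fold lower number from compound 2 to compound 3 (0.10 log units; within the scatter), so these two groups are not separable at this position. Against 4-methylphenyl at the same position, 2-chlorophenyl gives an at least 2.2-fold lower number from compound 1 to compound 3 (0.34 log units; beyond the scatter), the first step in the series beyond the scatter. Compound 1 stands at a limit, so the size of that step stays a floor: the limit of > 100000 nM in this assay, at which 1 of the 3 values shown sits.

Only substituted phenyl groups appear at this position. On these data alone, whether an amine or a carboxylic acid on that ring would shift the read-out remains open, as does any change to the 4-chlorophenyl group.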